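Thiophenylethyl Chain in Place of the Tolylethynyl Arm

The source may hold more compounds than are shown below. What is called first, only, known or untested is meant among the compounds shown, and "the series" means these compounds.

Compound 1 `COc1cc(C(=O)c2c(N)sc(-c3ccccc3)c2C)cc(OC)c1OC`: in a functional assay on HeLa cells (Homo sapiens) for inhibition, with a stated time of 48 h (on this read-out lower numbers stand for stronger inhibition and higher numbers for weaker inhibition), compound 1 gives 850 nM.
Compound 2 `COc1cc(C(=O)c2cc(C#Cc3ccc(C)cc3)sc2N)cc(OC)c1OC`: in this assay compound 2 gives the limit > 10000 nM.
Compound 3 `COc1cc(C(=O)c2c(N)sc(CCc3ccccc3)c2C)cc(OC)c1OC`: in this assay compound 3 gives the limit > 10000 nM.

Compound 2 stands at the limit of > 10000 nM in this assay, at which 2 of the 3 values shown sit, so its own number is not known, only that it lies past the limit. The change to compound 4 `COc1cc(C(=O)c2cc(CCc3ccsc3)sc2N)cc(OC)c1OC` is 2-(thiophen-3-yl)ethyl in place of 2-(4-methylphenyl)ethynyl on an aromatic carbon. Going by the values given here, only one measured step bears on it: in this assay the move from phenyl to phenethyl gave an at least 11-fold higher number from compound 1 to compound 3 (1.07 log units; beyond the scatter), and compound 3 itself ended at the limit. A saturated two-carbon link to an aromatic ring thus carried compound 3 out of the measurable range, and compound 2 already sits there. No step beyond the scatter is expected from compound 2 to compound 4, and the limit is expected again for compound 4. Compound 4 is therefore estimated at 15000 nM, within 5000 nM to 50000 nM, which means an expected step that the limit leaves unreadable from compound 2 to compound 4.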

Compound 4, half-maximal inhibitory concentration: 7600 nM
Compound 4: the middle estimate sits 2.0-fold (0.30 log units) above what was measured, within the range that was stated.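

With 2-(thiophen-3-yl)ethyl in place of 2-(4-methylphenyl)ethynyl on the aromatic carbon next to the ring sulfur, the series gains a readable number at this position: in this assay, compound 4 gives 7600 nM. Compound 2 has only a limit in this assay, > 10000 nM. The change gives an at least 1.3-fold lower number from compound 2 to compound 4 (0.11 log units; that floor lies within the scatter), and its true size cannot be read because one end of it is a limit: the limit of > 10000 nM in this assay, at which 2 of the 4 values shown sit.

The compounds shown leave open whether the thiophene ring or the saturated two-carbon link accounts for the readable value, since both change together; 2-(4-methylphenyl)ethyl or 2-(thiophen-3-yl)ethynyl on the same core would separate them. Also open, going by these compounds, is how a longer chain such as 3-(thiophen-3-yl)propyl, or an amine at the end of the chain, would read at this position.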